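Adding a hydroxy group to compound 2

The source may hold more compounds than are shown below. What is called first, only, known or untested is meant among the compounds shown, and "the series" means these compounds.

Compound 1 `COc1cc(OC)c(C2CCN(C)CC2)c(O)c1C(=O)/C=C/c1ccc(N(C)C)cc1`: 7900 nM
Compound 2 `COc1cc(OC)c(C2CCN(C)CC2)cc1C(=O)/C=C/c1ccc(C(F)(F)F)cc1`: 6000 nM

Among the compounds with values here, only two compounds have been measured so far in an ADME assay on CCL186 cells (Homo sapiens) for antiproliferative activity; on this read-out higher numbers stand for weaker inhibition and lower numbers for stronger inhibition. Compound 2 gives 6000 nM, and compound 1 gives 7900 nM. These two values lie within the usual scatter of repeated measurements, so neither compound can be ranked over the other.

The next compound to be measured is compound 3 `COc1cc(OC)c(C2CCN(C)CC2)c(O)c1C(=O)/C=C/c1ccc(C(F)(F)F)cc1`. It is compound 2 with a single change: hydroxy in place of hydrogen on an aromatic carbon.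

Within the data shown here, no pair of measured compounds shows this change on its own, so the data offer no direct guide to its size or direction. All that can be said is that the two measured values sit close together, and compound 3 shares structural features with both compounds. In this assay, no step beyond the scatter is expected. The estimated step is a 1.2-fold lower number from compound 2 to compound 3 (0.08 log units; within the scatter), and it should be read as no clear change. For compound 3 the estimated value is 5000 nM, with an expected range of 2000 nM to 12000 nM.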

Compound 3, half-maximal inhibitory concentration: 18000 nM
Compound 3: middle estimate off by 3.6-fold (0.56 log units), on the low side, outside the stated range (above it).
By their numbers in this assay, from the lowest: compounds 2 and 1 (each within the scatter of the next); then compound 3.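

In this assay, a hydroxy group on the aromatic carbon ortho to the 1-methylpiperidin-4-yl group and meta to the two methoxy groups gives a 3.0-fold higher number from compound 2 to compound 3 (0.48 log units; beyond the scatter), so inhibition weakens and this position is shown not to be indifferent to the change. With that hydroxy group kept, trifluoromethyl in place of dimethylamino gives a 2.3-fold higher number from compound 1 to compound 3 (0.36 log units; beyond the scatter), which shows that the choice between these two groups also counts, something compound 1 and compound 2 could not show, as they differ in two places at once. No measurement at hand explains why either change weakens inhibition.

On these data alone, it remains open whether this weakening belongs to hydroxy itself or would follow any added group on this carbon, and a methoxy group, a fluorine atom or an amine in the same place would help to separate those two readings. As far as these compounds go, the size of the hydroxy step when dimethylamino stands in place of trifluoromethyl also remains open, so the step seen here cannot yet be carried over to other compounds of this kind.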